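A Sulfanyl Chain Returns to the Saturated Ring Carbon

A few compounds are considered here, and "the series" means these few. Any claim that something is new, unique, unknown or untested is made for them only; others in the source may bear on it.

Compound 2 `CC1(Cc2ccccc2)C(=O)N(c2ccccc2)c2ncccc21` was tested in a functional assay on the whole organism (Pleural cavity) for inhibition, with Rattus norvegicus as the target, at a dose of 25 mg/kg (on this read-out lower numbers stand for less inhibition and higher numbers for more inhibition at the one dose given (going by the name of the read-out)), where compound 2 gives 9%. That is the lowest of the two numbers shown; the nearest is compound 1 `CSC1(C)C(=O)N(c2ccccc2)c2ncccc21`, which in this assay gives 34%. Going by the values given here, the one measured step, a number 25 percentage points lower from compound 1 to compound 2 (beyond the scatter), bears directly on the next move. Compound 3 `COCCSC1(C)C(=O)N(c2ccccc2)c2ncccc21` has not yet been measured; it differs from compound 2 by (2-methoxyethyl)sulfanyl in place of benzyl on a saturated ring carbon. Since compound 3 brings a sulfanyl group back to the saturated ring carbon, as in compound 1, the step already seen from compound 1 to compound 2 is expected to be partly reversed. Compound 3 is therefore expected to show a step of a number 18 percentage points higher from compound 2 to compound 3 (beyond the scatter), upward. Among the compounds with values here, the (2-methoxyethyl)sulfanyl group is not the methylsulfanyl of compound 1, and only two compounds are known, so the size of that step is uncertain. The estimate for compound 3 in this assay is 27%, within a range from 8% to 46%.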

Compound 3, a percentage reported as inhibition, in the whole organism at one dose (the size of the read-out at that dose, not a potency): 26%
Beside the measured number, compound 3's estimate is 1 percentage points above it, and the stated range covers the measured number.
By their numbers in this assay, from the lowest: compound 2; then compounds 3 and 1 (each within the scatter of the next).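

Going by these compounds alone, the methylsulfanyl of compound 1 turns out not to be the only sulfanyl group that gives a number above that of the benzyl compound on the saturated ring carbon: (2-methoxyethyl)sulfanyl in place of benzyl gives a number 17 percentage points higher from compound 2 to compound 3 (beyond the scatter) in this assay. Methoxymethyl in place of hydrogen on the saturated chain carbon bound to the sulfur gives a number 8 percentage points lower from compound 1 to compound 3 (within the scatter), so this read-out does not separate the two sulfanyl groups. Nothing measured here explains the gap between the sulfanyl groups and benzyl.

On these data alone, it remains open whether the sulfur itself is needed, or whether a methoxy or ethoxy group joined through oxygen on the same ring carbon would do as well as compound 1 and compound 3. Also open, as far as these compounds go, is how a longer chain, or an amine or carboxylic acid at the end of the sulfanyl chain, would fare at this dose.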